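A few compounds are considered here, and "the series" means these few. Any claim that something is new, unique, unknown or untested is made for them only; others in the source may bear on it.

Of the compounds shown here, two have been measured so far. Compound 1 `N=C(N)NCCC[C@H](NC(=O)CN(c1nc(Cl)nc2[nH]cnc12)C1CC1)C(=O)OCc1ccccc1` gives 30.4% in a functional assay on the whole organism (Tail, strain ICR) with Mus musculus as the target, in the tail flick test, with a stated time of 90 min, at a dose of 25 umol/kg by the oral route; on this read-out lower numbers stand for a weaker effect and higher numbers for a stronger effect at the one dose given. Compound 2 `O=C(CN(c1ncnc2c1ncn2C1CCCCO1)C1CC1)NCC(=O)OCc1ccccc1` gives 25.9% in this assay. Compound 1 carries the upper of these two readings, but its gap to compound 2 lies within the usual scatter, so the two cannot be told apart on this evidence. Compound 3 `NC(=O)CC[C@H](NC(=O)CN(c1nc(Cl)nc2[nH]cnc12)C1CC1)C(=O)OCc1ccccc1` has not been measured; it differs from compound 1 by a group of 3 heavy atoms (1 carbon, 1 nitrogen, 1 oxygen; no ring) in place of a group of 5 heavy atoms (2 carbon, 3 nitrogen; no ring), on a saturated chain carbon, three bonds along the chain from an amide-type nitrogen and a carbonyl carbon. Within the data shown here, no measured pair shows the effect of such a change, so there is no basis for expecting a step beyond the scatter in either direction. The step from compound 1 to compound 3 is therefore estimated as a number 4.4 percentage points lower from compound 1 to compound 3 (within the scatter), and compound 3 is expected to give about 26%, most likely between 12% and 40%.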

Compound 3, a percentage reported as activity, at one dose (the size of the read-out at that dose, not a potency): 42.8%
Estimate against measurement, compound 3: 16.8 percentage points below, outside the stated range (above it).
By their numbers in this assay, from the lowest: compounds 2 and 1 (each within the scatter of the next); then compound 3.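

At the saturated chain carbon, three bonds along the chain from an amide-type nitrogen and a carbonyl carbon, the choice of group matters in this assay: carbamoyl in place of the group of 5 heavy atoms gives a number 12.4 percentage points higher from compound 1 to compound 3 (beyond the scatter) on the shared core. The group of 5 heavy atoms is therefore not needed for a reading at this level. Nothing measured here explains the step.

As far as these compounds go, whether a carboxylic acid or an amine at this place would read higher or lower stays open. So does the effect of a longer chain carrying the carbamoyl.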